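This account rests on a few compounds, and the source may have more. Where it says the series, first, only, none or still open, it means among the compounds named here.

Measured so far:
Compound 1, `Nc1scc(CN2CCN(c3cccc(Cl)c3Cl)CC2)c1C(=O)c1ccc(Cl)cc1`, gives 1% in a functional assay on CHO cells with adenosine receptor A1 (Homo sapiens) as the target, read by cAMP accumulation and immunoassay, with a stated time of 6 min, tested at 0.01 uM; on this read-out higher numbers stand for a weaker effect at the one concentration tested and lower numbers for a stronger effect.
Compound 2, `Nc1scc(CN2CCN(c3ccc(Cl)cc3F)CC2)c1C(=O)c1ccc(Cl)cc1`, gives -9.2% in this assay.

Among the measured compounds shown here, compound 2 stands at the lower of the two numbers; its only neighbour is compound 1, separated from it by the step of a number 10.2 percentage points lower from compound 1 to compound 2 (beyond the scatter). Compound 3, `COc1ccc(N2CCN(Cc3csc(N)c3C(=O)c3ccc(Cl)cc3)CC2)cc1`, has not yet been measured. It differs from compound 2 in one place: 4-methoxyphenyl in place of 4-chloro-2-fluorophenyl on an amine nitrogen in a ring. For the measured compounds named here, the one measured step that bears on this change is the one from compound 1 to compound 2, which also swapped the group on the same ring nitrogen and shifted the number by a number 10.2 percentage points lower from compound 1 to compound 2 (beyond the scatter), a modest move. Both measured numbers sit close to no effect, so the new swap is expected to shift the result only a little in this assay, the expected step being a number 6.2 percentage points higher from compound 2 to compound 3 (within the scatter). Compound 3 is therefore estimated at -3%, within a range from -20% to 14%.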

Compound 3, a percentage reported as activity, at one concentration (the size of the read-out at that concentration, not a potency): -1.2%
Compound 3: middle estimate off by 1.8 percentage points, on the low side; measured number inside the range.
By their numbers in this assay, from the lowest: compounds 2, 3 and 1 (each within the scatter of the next, the first and the last beyond it).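

On the ring nitrogen, 4-methoxyphenyl carries no halogen and adds a hydrogen-bond acceptor, yet in this assay it cannot be told apart from either halogen-bearing group: the steps are a number 8 percentage points higher from compound 2 to compound 3 (within the scatter) and a number 2.2 percentage points lower from compound 1 to compound 3 (within the scatter). Replacing the halogens with a methoxy group on this phenyl ring therefore gives no readable change, although the two halogen-bearing compounds, compound 1 and compound 2, do differ by slightly more than the scatter. Nothing measured here explains these numbers.

From the compounds shown here alone, all three compounds carry a substituted phenyl ring on that nitrogen, so it remains open whether an unsubstituted phenyl, a pyridine or a plain alkyl chain there would leave the read-out equally unchanged. With only one concentration shown, whether these compounds would have a stronger or weaker effect at other concentrations also remains open.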